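The compounds below may be only part of what the source reports. "The series", "measured", "known", "first", "only" and "open" are said of these compounds alone.

Of the compounds shown here, two have numbers so far in a functional assay on A549 cells (Homo sapiens) for cytotoxicity, read by WST assay, with a stated time of 48 h (a higher number here means a weaker inhibitor, a lower number a stronger inhibitor), and they share most of their structure. Compound 1 `COc1ccc2c(/C=C(\C#N)C(=O)c3c[nH]c4ccccc34)c[nH]c2c1` gives 5800 nM and compound 2 `N#C/C(=C\c1c[nH]c2ccccc12)C(=O)c1c[nH]c2ccccc12` gives 22000 nM as the higher of the two numbers, which makes compound 2 the weaker inhibitor of the pair. Compound 3 `COc1ccc(Cn2cc(/C=C(\C#N)C(=O)c3c[nH]c4ccccc34)c3ccccc32)cc1` arises from compound 2 by one change, 4-methoxybenzyl in place of hydrogen on an aromatic nitrogen. Among the measured compounds shown here, the only measured step to lean on, hydrogen in place of methoxy on an aromatic carbon, is a 3.8-fold higher number from compound 1 to compound 2 (0.58 log units; beyond the scatter) and it is modest. It concerns carbon rather than nitrogen and a much smaller group, so it is a weak guide. Since compound 1 at 5800 nM carries a methoxy and stands lower, a modest step to a lower number is expected in this assay with wide uncertainty. The expected size is a 3.7-fold lower number from compound 2 to compound 3 (0.56 log units; beyond the scatter) by this estimate. Compound 3 is estimated at 6000 nM with an expected range from 1500 nM to 22000 nM as its likely span.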

Compound 3, half-maximal inhibitory concentration: > 50000 nM
Compound 3 was reported as a limit; the forecaster's own chance of this, stated with the estimate: 15%; middle value at least 8.3-fold (0.92 log units) from the limit.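

Putting 4-methoxybenzyl on the aromatic nitrogen, in place of hydrogen, weakens the compound in this assay, with an at least 2.2-fold higher number from compound 2 to compound 3 (0.35 log units; beyond the scatter). The earlier step concerned only a methoxy on an aromatic carbon, where the compound carrying the group had the lower number, so this change on nitrogen runs the other way. The value for compound 3 is a limit, so the step has a known minimum but no known full size: the limit of > 50000 nM in this assay, at which 1 of the 3 values shown sits.

The compounds shown leave open whether any group on this nitrogen weakens the compound or only this one, and a methyl or a longer chain ending in an amine would help to settle that. They also leave open whether a plain benzyl, without the methoxy, would behave in the same way.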